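The source may report more compounds than this note shows. Statements on the series, on what has been measured and on what is new or still open speak of the compounds shown alone.

Measured compounds:
- compound 1 `O=C(/C=C/c1cccc(Cl)c1Cl)Nc1cc2c(Nc3ccc(F)c(Cl)c3)ncnc2cc1O[C@H]1CCOC1` — in a functional assay on PC-3 cells (Homo sapiens) for cytotoxicity, read by MTT assay, with a stated time of 72 h (a lower number here means a stronger inhibitor, a higher number a weaker inhibitor), compound 1 gives 27500 nM
- compound 2 `COc1cc2ncnc(Nc3ccc(F)c(Cl)c3)c2cc1NC(=O)/C=C/c1ccc(C#N)cc1` — in this assay compound 2 is reported as "not active" (no number reported), with no number attached
- compound 3 `COc1ccc(/C=C/C(=O)Nc2cc3c(Nc4ccc(F)c(Cl)c4)ncnc3cc2OC)cc1` — in this assay compound 3 is likewise reported as "not active" (no number reported), again without a number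

Among the measured compounds shown here, compound 1 therefore stands alone as the only entry with a numerical value in this assay; the two other entries of the series carry no figure, so no step between measured compounds can be drawn from them, and nothing about the other two can be set against compound 1 beyond the bare fact that compound 1 did return a number where they did not.

The next compound to be measured is compound 4 `O=C(/C=C/c1ccccc1[N+](=O)[O-])Nc1cc2c(Nc3ccc(F)c(Cl)c3)ncnc2cc1O[C@H]1CCOC1`. It differs from compound 1 in one place: 2-nitrophenyl in place of 2,3-dichlorophenyl on a double-bonded chain carbon bound to a double-bonded chain carbon. The shared core, the amide linker and the double-bonded chain are unchanged.

For the measured compounds named here, with no measured step available, the size of the change from compound 1 to compound 4 cannot be anchored. The aryl groups of compound 2 and compound 3 both returned no number, and the group of compound 1 returned only a weak value, so a move of at most modest size in either direction, and quite possibly none beyond the scatter, is expected for a 1.1-fold higher number from compound 1 to compound 4 (0.04 log units; within the scatter). Compound 4 is accordingly estimated at 30000 nM, within the range 8000 nM to 100000 nM.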

Compound 4, half-maximal inhibitory concentration: 7760 nM
The estimate for compound 4 lay 3.9-fold (0.59 log units) above the measured number; the measured number lies below the stated range.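

In this assay, among the compounds shown here, the aryl group on the double-bonded chain carbon bound to a double-bonded chain carbon proves to be a place where the read-out moves: 2-nitrophenyl in place of 2,3-dichlorophenyl gives a 3.5-fold lower number from compound 1 to compound 4 (0.55 log units; beyond the scatter), the first step that can be read at all. With the shared core, the amide linker and the double-bonded chain unchanged, this step belongs to the aryl exchange alone, and compound 4 at 7760 nM shows that this position can carry a group other than 2,3-dichlorophenyl and still return a number. No measurement in hand bears on what lies behind the step, so it stands as an observation only.

For the compounds shown here, the single step changes two things at once, the two chlorines leaving and the nitro group entering, so their shares stay unresolved; an unsubstituted phenyl or an aminophenyl at this place would begin to separate them. Steps involving compound 2 and compound 3 cannot be read, so it remains open whether the aryl exchange would behave the same way with the methoxy group these two compounds carry.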